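A few compounds are considered here, and "the series" means these few. Any claim that something is new, unique, unknown or untested is made for them only; others in the source may bear on it.

Compound 2 `Cc1nc(C(=O)Nc2ccc(Cl)c(-c3nnc4c(Cl)cccn34)c2)cs1` carries a 2-methyl-1,3-thiazol-4-yl group on the carbonyl carbon of the amide on the shared core. In a functional assay on A549 cells (Homo sapiens) for antiproliferative activity, read by MTT assay, with a stated time of 72 h (on this read-out lower numbers stand for stronger inhibition and higher numbers for weaker inhibition), compound 2 gives only a limit of the assay, > 100000 nM. This places compound 2 at the limit of > 100000 nM in this assay, at which 2 of the 3 values shown sit. Compound 1 `O=C(Nc1ccc(Cl)c(-c2nnc3c(Cl)cccn23)c1)c1ccccc1`, with a plain phenyl on the carbonyl carbon, gives 76900 nM in this assay, and from it the step of an at least 1.3-fold higher number from compound 1 to compound 2 (0.11 log units; that floor lies within the scatter) follows. Compound 3 `CS(=O)(=O)c1ccc(C(=O)Nc2ccc(Cl)c(-c3nnc4c(Cl)cccn34)c2)cc1` likewise gives only a limit in this assay, > 100000 nM. The step of an at least 1.3-fold higher number from compound 1 to compound 3 (0.11 log units; that floor lies within the scatter) is of the same kind, while the step that the two limits leave unreadable from compound 2 to compound 3.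

Compound 4 `O=C(Nc1ccc(Cl)c(-c2nnc3c(Cl)cccn23)c1)c1ccc(F)cc1Cl` is not yet measured. It differs from compound 2 as follows: 2-chloro-4-fluorophenyl in place of 2-methyl-1,3-thiazol-4-yl on a carbonyl carbon. For the measured compounds named here, none of the measured steps makes this exact change. The nearest guide is compound 1, whose phenyl amide gives 76900 nM. Compound 2 sits only at a limit. The expected step of an at least 2.0-fold lower number from compound 2 to compound 4 (0.30 log units; that floor lies within the scatter) can thus be read only as a return toward the range of compound 1. Compound 4 is therefore estimated at 50000 nM, within 15000 nM to 150000 nM.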

Compound 4, half-maximal inhibitory concentration: > 100000 nM
Compound 4 gave a limit, no number; the forecaster's own chance of this, stated with the estimate: 35%; middle value at least 2.0-fold (0.30 log units) from the limit.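

In this assay compound 4 also gives a limit and not a number, so a six-membered aromatic ring of carbon only on this carbonyl carbon does not by itself give a readable value, with the plain phenyl of compound 1 the one case that does. For the compounds shown here, the change an at least 1.3-fold higher number from compound 1 to compound 4 (0.11 log units; that floor lies within the scatter) is the only readable step, and it gives just a floor; the steps to compound 4 from compound 2 and from compound 3 cannot be read, since both ends are limits. Three different groups on this carbonyl carbon now end at the same place: the limit of > 100000 nM in this assay, at which 3 of the 4 values shown sit.

Going by these compounds, how far a phenyl carrying only the chlorine or only the fluorine would sit from compound 1 stays open. So does whether a ring bearing an amine or a carboxylic acid would give a lower number than compound 1.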